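Replacing the chlorophenyl on the triazole with a hydroxypropyl chain

The source may report more compounds than this note shows. Statements on the series, on what has been measured and on what is new or still open speak of the compounds shown alone.

Of the compounds shown here, two sharing one core have been tested so far. Compound 1 `CN(CCNCc1cn(-c2ccc(Cl)cc2)nn1)CCNc1ccnc2cc(Cl)ccc12` gives 9500 nM in a functional assay on HCC827 cells (Homo sapiens) for antiproliferative activity, read by sulforhodamine B assay, with a stated time of 72 h (on this read-out lower numbers stand for stronger inhibition and higher numbers for weaker inhibition), and compound 2 `CN(CCNCc1cn(-c2cccc(Cl)c2)nn1)CCNc1ccnc2cc(Cl)ccc12` gives 9400 nM. The only step between them, a 1.0-fold lower number from compound 1 to compound 2 (0.00 log units; within the scatter), moves a chlorine around the phenyl ring; on the numbers shown compound 2 has the lowest value of the two, but this is not a difference of any weight. Compound 3 `CN(CCNCc1cn(CCCO)nn1)CCNc1ccnc2cc(Cl)ccc12` is not yet measured. It differs from compound 2 by 3-hydroxypropyl in place of 3-chlorophenyl on an aromatic nitrogen. Within the data shown here, no measured step bears on the exchange of an aromatic ring for an open chain bearing a hydroxyl, so the single step available, a repositioning of chlorine, offers no guide. In the absence of such information, compound 3 is expected to stay close to compound 2, with the step of a 1.3-fold higher number from compound 2 to compound 3 (0.11 log units; within the scatter) estimated to lie within or near the scatter. Compound 3 is therefore estimated at 12000 nM, with a range from 4000 nM to 35000 nM.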

Compound 3, half-maximal inhibitory concentration: > 200000 nM
Compound 3: a limit, no number; the forecaster's own chance of this, stated with the estimate: 15%; middle value at least 16-fold (1.22 log units) from the limit.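

In this assay the result for compound 3 is a limit of the assay and not a number: the limit of > 200000 nM in this assay, at which 1 of the 3 values shown sits. Moving the chlorine around the phenyl ring left the read-out within the scatter, but exchanging the whole ring on this aromatic nitrogen for 3-hydroxypropyl is a large change, with an at least 21-fold higher number from compound 2 to compound 3 (1.32 log units; beyond the scatter) and an at least 21-fold higher number from compound 1 to compound 3 (1.32 log units; beyond the scatter). Among these three compounds, then, the position tolerates a shift of the chlorine but not this replacement of the ring by an open chain.

The change removes the ring and brings in the hydroxyl in a single step, and the compounds shown do not tell these two apart. Going by these compounds, whether a plain propyl chain or an unsubstituted phenyl on this nitrogen would sit with compound 2 or with compound 3 stays open.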